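Chain extension in a purine-derived series: compound 2 to compound 3

The compounds below may be only part of what the source reports. "The series", "measured", "known", "first", "only" and "open" are said of these compounds alone.

Compound 1 `Cn1c[n+](Cc2ccccc2)c2/c(=N/OC(C)(C)C)[nH]cnc21` has no result in a functional assay on CEM/s cells (Homo sapiens) for cytotoxicity; a higher number here means a weaker inhibitor, a lower number a stronger inhibitor: for compound 1 the entry reads "not determined" (no result reported). Going by the values given here, compound 2 `CO/N=c1\[nH]cnc2c1[n+](C/C=C(\C)CCC=C(C)C)cn2C` is therefore the only compound with a number: in this assay compound 2 gives 27400 nM. Compound 3 `CO/N=c1\[nH]cnc2c1[n+](C/C=C(\C)CC/C=C(/C)CCC=C(C)C)cn2C` differs from compound 2 by 3-methylbut-2-en-1-yl in place of hydrogen on a saturated chain carbon bound to a double-bonded chain carbon. Among the compounds with values here, no measured pair covers a change of this kind, so the size of the step is an open question; a step of a 1.8-fold lower number from compound 2 to compound 3 (0.26 log units; within the scatter) toward a stronger inhibitor is expected, close to the usual scatter. Compound 3 is accordingly estimated at 15000 nM in this assay, with a range from 5000 nM to 45000 nM.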

Compound 3, half-maximal inhibitory concentration: 1230 nM
Compound 3: middle estimate off by 12-fold (1.09 log units), on the high side; the whole stated range lies above it.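

Extending the chain with 3-methylbut-2-en-1-yl, on a saturated chain carbon bound to a double-bonded chain carbon, gives in this assay a 22-fold lower number from compound 2 to compound 3 (1.35 log units; beyond the scatter). Going by these compounds alone, this position therefore responds strongly to chain extension, which compound 2 alone, as the only earlier number, could not show. Nothing at hand accounts for the size of this step.

Still open, as far as these compounds go, is whether a longer chain than that of compound 3 would lower the number further or reverse the trend. Also open, from the compounds shown here alone, is whether a fully saturated chain, without the double bonds, or a chain ending in a carboxylic acid would give a similar step.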